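The source may report more compounds than this note shows. Statements on the series, on what has been measured and on what is new or still open speak of the compounds shown alone.

Measured so far:
compound 1 `CCCCCCCC/C=C\CCCCCCCCNC(=O)Nc1c(C(C)C)cccc1C(C)C`, 28 nM 
compound 2 `CCCCCCCCCCCCCCCCCCNC(=O)Nc1c(C(C)C)cccc1C(C)C`, 48 nM 
compound 3 `CCCCCCCCCCNC(=O)Nc1c(C)cccc1C(C)C`, 210 nM 

In an assay on microsomes from intestinal mucosa for inhibition of acyl-CoA:cholesterol acyltransferase (Oryctolagus cuniculus) (a lower number here means a stronger inhibitor, a higher number a weaker inhibitor), compound 3 gives the highest number of the three. Compound 4 `CCCCCCCCCCNC(=O)Nc1c(C(C)C)cccc1C(C)C` differs from it in one place: isopropyl in place of methyl on an aromatic carbon. Within the data shown here, no measured pair shows this exchange; the only recorded step, a 1.7-fold higher number from compound 1 to compound 2 (0.23 log units; within the scatter), concerns the chain and lies within the scatter. Compounds 1 and 2 carry two isopropyl groups on the core and give lower numbers than compound 3, but they also carry a longer chain, so their values only hint at the direction. A step toward a lower number is expected, a 1.9-fold lower number from compound 3 to compound 4 (0.28 log units; within the scatter), with wide uncertainty. Compound 4 is estimated at 110 nM, ranging from 35 nM to 350 nM.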

Compound 4, half-maximal inhibitory concentration: 56 nM
The estimate for compound 4 lay 2.0-fold (0.29 log units) above the measured number; the range from low to high includes it.
By their numbers in this assay, from the lowest: compounds 1, 2 and 4 (each within the scatter of the next); then compound 3.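

In this assay, isopropyl in place of methyl on this aromatic carbon gives a 3.8-fold lower number from compound 3 to compound 4 (0.57 log units; beyond the scatter), so this position responds to the size of the group it carries, at least for this pair. Despite its shorter chain, compound 4 stays level with the two longer-chain compounds: a 1.2-fold higher number from compound 2 to compound 4 (0.07 log units; within the scatter) and a 2.0-fold higher number from compound 1 to compound 4 (0.30 log units; within the scatter). Nothing available explains why the exchange has this effect. Going by these compounds, whether tert-butyl or an amine on this carbon would match isopropyl remains open, as does how a chain shorter than that of compound 4 would fare.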